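Chloro on the aryl group: transfer from one core to another

The compounds below may be only part of what the source reports. "The series", "measured", "known", "first", "only" and "open" are said of these compounds alone.

Compound 2 `Cc1nc(-c2ccccc2)sc1C(=O)CSc1nc(N)c(C#N)c(-c2ccccc2)n1` carries an unsubstituted aromatic ring on its core, and compound 1 `Cc1nc(-c2ccccc2)sc1C(=O)CSc1nc(N)c(C#N)c(-c2ccc(Cl)cc2)n1` carries the chlorinated version of that ring. In a functional assay on U-87MG ATCC cells for antiproliferative activity against U-87 MG (Homo sapiens), read by MTT assay, with a stated time of 48 h (a higher number here means a weaker inhibitor, a lower number a stronger inhibitor), compound 2 gives 29000 nM, while compound 1 gives 10800 nM. Going by the values given here, the single change between the two is chloro in place of hydrogen on an aromatic carbon, and it produced a 2.7-fold lower number from compound 2 to compound 1 (0.43 log units; beyond the scatter).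

Compound 3 `COc1ccc(-c2nc(SCC(=O)c3sc(-c4ccccc4)nc3C)[nH]c(=O)c2C#N)cc1OC` belongs to a different core; how the core of compound 3 differs from that of compound 2 is not broken down here. In this assay compound 3 gives 15300 nM, a number that sits within the usual scatter of both compound 1 and compound 2, so no order among the three can be stated.

Compound 4 `COc1ccc(-c2nc(SCC(=O)c3sc(-c4ccc(Cl)cc4)nc3C)[nH]c(=O)c2C#N)cc1OC` is the chlorinated counterpart of compound 3. The change is chloro in place of hydrogen on an aromatic carbon, placed on the same kind of position as in the pair of compound 2 and compound 1, so it is the same change carried onto the other core. Among the compounds with values here, with only one earlier example of this change, and that on a different core, the transfer is uncertain, but the earlier step is the only guide available. The step expected from compound 3 to compound 4 in this assay is a 2.2-fold lower number from compound 3 to compound 4 (0.34 log units; beyond the scatter), resting on compound 2 to compound 1, which showed a 2.7-fold lower number from compound 2 to compound 1 (0.43 log units; beyond the scatter). Compound 4 is therefore estimated at 7000 nM, with a plausible range from 3000 nM to 17000 nM.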

Compound 4, half-maximal inhibitory concentration: 38600 nM
For compound 4 the middle estimate is 5.5-fold (0.74 log units) below the measured one; the whole stated range lies below it.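

On the core of compound 3, in this assay, chloro in place of hydrogen on an aromatic carbon gives a 2.5-fold higher number from compound 3 to compound 4 (0.40 log units; beyond the scatter), so phenyl to 4-chlorophenyl does not lower the number here as it did on the core of compound 2. Set side by side, the same change moves the number in opposite directions on the two cores, and the gap between the two steps is larger than repeated measurements would explain: the same change on two cores in this assay, a 2.7-fold lower number (0.43 log units; beyond the scatter) from compound 2 to compound 1 and a 2.5-fold higher number (0.40 log units; beyond the scatter) from compound 3 to compound 4, 6.8-fold (0.83 log units) apart, beyond the scatter of two such steps. This shows that, in this series, the effect of the change cannot be assumed to carry from one core to another, but with one pair per core it gives no general rule, does not show what in the core of compound 3 accounts for the reversal, and does not exclude that the aromatic ring carrying the chloro, which is not the same part of the molecule in the two pairs, plays a role.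

Open, from the compounds shown here alone, is whether the reversal belongs to chloro itself or would also appear with bromo, fluoro or an amine on the same aromatic carbon. Also open, going by these compounds, is how each core responds when the chloro is placed on the other aromatic ring, which would separate the effect of the core from that of the ring carrying the group.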